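The source may hold more compounds than are shown below. What is called first, only, known or untested is meant among the compounds shown, and "the series" means these compounds.

Going by the values given here, in an ADME assay on K562 cells (Homo sapiens) for antiproliferative activity (a lower number here means a stronger inhibitor, a higher number a weaker inhibitor), compound 1 `COc1ccc2nccc(CC[C@H]3OC[C@H](NCc4cc5c(cn4)OCCO5)CO3)c2c1` gives 40000 nM, the higher of the two numbers known so far, while compound 2 `COc1ccc2nccc(CC[C@H]3OC[C@H](NCc4ccc5c(c4)OCCO5)CO3)c2c1` gives 7400 nM. Compound 3 `COc1ccc2nccc(CC[C@H]3OC[C@H](NCc4cc5c(cn4)OCCC5)CO3)c2c1` differs from compound 1 on a saturated chain carbon bound to an amine nitrogen: a group of 10 heavy atoms (8 carbon, 1 nitrogen, 1 oxygen; one six-membered non-aromatic ring with 1 hetero atom, one six-membered aromatic ring with 1 hetero atom) in place of a group of 10 heavy atoms (7 carbon, 1 nitrogen, 2 oxygen; one six-membered non-aromatic ring with 2 hetero atoms, one six-membered aromatic ring with 1 hetero atom), on a saturated chain carbon bound to an amine nitrogen. Among the compounds with values here, only one measured step bears on this change, and only indirectly: a 5.4-fold lower number from compound 1 to compound 2 (0.73 log units; beyond the scatter). That step also exchanges a group of the same size at the same place, but it alters the aromatic ring, whereas compound 3 keeps the six-membered aromatic ring with 1 hetero atom and alters the non-aromatic ring. A step in the same direction but smaller is therefore expected in this assay, possibly none beyond the scatter. The estimated step is a 2.0-fold lower number from compound 1 to compound 3 (0.30 log units; within the scatter). The expected value for compound 3 is 20000 nM, with an estimated range from 7000 nM to 50000 nM.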

Compound 3, half-maximal inhibitory concentration: 32000 nM
Beside the measured number, compound 3's estimate is 1.6-fold (0.20 log units) below it; the measured number falls inside the stated range.
By their numbers in this assay, from the lowest: compound 2; then compounds 3 and 1 (each within the scatter of the next).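

In this assay the exchange on a saturated chain carbon bound to an amine nitrogen, from the group with 2 hetero atoms in its non-aromatic ring to the group with 1, gives a 1.3-fold lower number from compound 1 to compound 3 (0.10 log units; within the scatter) and so leaves compound 1 and compound 3 level within the scatter. Compound 2, whose group has an aromatic ring of carbon only, stays apart from both, with a 4.3-fold higher number from compound 2 to compound 3 (0.64 log units; beyond the scatter) now standing beside the earlier 5.4-fold lower number from compound 1 to compound 2 (0.73 log units; beyond the scatter); among these three compounds, only the group with that carbon-only aromatic ring gives a separate number. Nothing measured here accounts for these numbers.

On these data alone, whether the non-aromatic ring with 1 hetero atom would read the same on an aromatic ring of carbon only stays open. So does how a plain phenyl group or a morpholine would read at this place.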